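Stilbene to anilide in a bile acid receptor agonist series

The source may report more compounds than this note shows. Statements on the series, on what has been measured and on what is new or still open speak of the compounds shown alone.

Going by the values given here, compound 1 `CC(C)(C)c1onc(-c2c(Cl)cccc2Cl)c1COc1ccc(/C=C/c2cccc(C(=O)O)c2)c(Cl)c1` is one of two compounds measured in a functional assay on HEK293 cells for agonist activity at Bile acid receptor (Homo sapiens); a higher number here means that more compound is needed for the effect, a lower number that less compound is needed. In this assay compound 1 gives 1300 nM, the lowest of the two numbers. The nearest is compound 2 `CCCN(C(=O)c1ccc(OCc2c(-c3c(Cl)cccc3Cl)noc2C(C)C)cc1Cl)c1cccc(C(=O)O)c1`, which in this assay gives 2100 nM; the two values lie within the scatter of each other, so no order between them can be claimed.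

Compound 3 `CC(C)(C)c1onc(-c2c(Cl)cccc2Cl)c1COc1ccc(C(=O)Nc2cccc(C(=O)O)c2)c(Cl)c1` has not yet been measured. It differs from compound 1 in one place: (3-carboxyphenyl)carbamoyl in place of 2-(3-carboxyphenyl)ethenyl on an aromatic carbon. Among the compounds with values here, no measured pair shows this step, so its size has to be judged from the two values at hand. The anilide in compound 3 brings the series closer in kind to compound 2, whose value is 2100 nM, and the carboxyphenyl group is kept. The account therefore expects a modest loss, of the order of the gap between compound 1 and compound 2 or slightly more, as the step of a 1.9-fold higher number from compound 1 to compound 3 (0.28 log units; within the scatter). For compound 3 the estimate in this assay is 2500 nM, with a range from 800 nM to 8000 nM.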

Compound 3, half-maximal effective concentration: 1300 nM
The estimate for compound 3 lay 1.9-fold (0.28 log units) above the measured number, within the range that was stated.
By their numbers in this assay, from the lowest: compounds 1, 3 and 2 (each within the scatter of the next).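

In this assay, putting (3-carboxyphenyl)carbamoyl in place of 2-(3-carboxyphenyl)ethenyl, on the aromatic carbon ortho to a chloro group and para to a large group, gives no change at the digits printed from compound 1 to compound 3 (within the scatter). This single pair shows that, on the core of compound 1, this position takes the carbamoyl link as well as the ethenyl link while the 3-carboxyphenyl group stays in place, even though the entering group holds more hydrogen-bond donors and acceptors than the group it replaces. The data at hand offer no measurement that bears on why the two links read alike.

The compounds shown leave open whether a saturated two-carbon chain or a sulfonamide in place of the carbamoyl link would also read alike at this position, and whether a tetrazole could stand in for the carboxylic acid on the far ring. Going by these compounds alone, they also leave open whether the same exchange gives the same result on other cores, since this one pair on the core of compound 1 is the only reading of it.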